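Replacing sec-butyl with isopropyl: notes on compound 3

This account rests on a few compounds, and the source may have more. Where it says the series, first, only, none or still open, it means among the compounds named here.

Going by the values given here, in a functional assay on HBL-100 cells (Homo sapiens) for antiproliferative activity, read by sulforhodamine B assay, with a stated time of 48 h (on this read-out lower numbers stand for stronger inhibition of growth and higher numbers for weaker inhibition of growth), compound 2 (`CCCCCCCCC[C@@H](O)[C@@H](N)[C@@H](C)CC`) gives 13000 nM as the higher of the two numbers so far, while compound 1 (`CCCCCCCCCCCCCCC[C@@H](O)[C@@H](N)C(C)C`) gives 4900 nM as the lower, a gap beyond the scatter. Compound 3 (`CCCCCCCCC[C@@H](O)[C@@H](N)C(C)C`) differs from compound 2 by hydrogen in place of methyl on a saturated chain carbon, three bonds along the chain from an amine nitrogen. Among the compounds with values here, no measured pair isolates this change. The expected change in this assay is a 1.3-fold lower number from compound 2 to compound 3 (0.11 log units; within the scatter) and would be slightly downward, with none beyond the scatter. For compound 3 the estimate is 10000 nM with 4500 nM to 23000 nM as the expected range.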

Compound 3, concentration for 50% growth inhibition: 14000 nM
Beside the measured number, compound 3's estimate is 1.4-fold (0.15 log units) below it, and the stated range covers the measured number.
By their numbers in this assay, from the lowest: compound 1; then compounds 2 and 3 (each within the scatter of the next).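

In this assay, hydrogen in place of methyl on a saturated chain carbon, three bonds along the chain from an amine nitrogen, gives a 1.1-fold higher number from compound 2 to compound 3 (0.03 log units; within the scatter) and so sec-butyl and isopropyl read alike at this position. Going by these compounds alone, with isopropyl kept, hydrogen in place of hexyl on a saturated chain carbon gives a 2.9-fold higher number from compound 1 to compound 3 (0.46 log units; beyond the scatter) and is the only step here beyond the scatter. No evidence in hand bears on either step.

Still open, from the compounds shown here alone, is whether a chain longer than that of compound 1, or an amine in place of isopropyl, would move the number.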